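Series notes: chain substituent on the shared core, compound 4

The source may hold more compounds than are shown below. What is called first, only, known or untested is meant among the compounds shown, and "the series" means these compounds.

Measured values all come from a functional assay on the whole organism (strain ICR) for inhibition, with Mus musculus as the target, with a stated time of 16 h, at a dose of 10 mg/kg by the oral route; a lower number here means less inhibition, a higher number more inhibition at the dose given (going by the name of the read-out):
compound 1 `Cn1c(-c2ccccc2C(F)(F)F)nnc1C12CCC(CCS(=O)(=O)C(C)(C)C)(CC1)CC2` — 10%
compound 2 `Cn1c(-c2ccccc2C(F)(F)F)nnc1C12CCC(CNS(C)(=O)=O)(CC1)CC2` — 27%
compound 3 `Cn1c(-c2ccccc2C(F)(F)F)nnc1C12CCC(COc3ccc(S(C)(=O)=O)cc3)(CC1)CC2` — 28%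

Compound 3 holds the highest of the three numbers; against compound 2 the gap is within the scatter (a number 1 percentage points higher from compound 2 to compound 3 (within the scatter)), against compound 1 it lies beyond it (a number 18 percentage points higher from compound 1 to compound 3 (beyond the scatter)). Compound 4 `CC(F)CCCC12CCC(c3nnc(-c4ccccc4C(F)(F)F)n3C)(CC1)CC2` differs from compound 3 in one place: 3-fluorobutyl in place of 4-(methylsulfonyl)phenoxy on a saturated chain carbon bound to a saturated ring carbon. For the measured compounds named here, no measured step matches this change. The two steps beyond the scatter, a number 17 percentage points higher from compound 1 to compound 2 (beyond the scatter) and a number 18 percentage points higher from compound 1 to compound 3 (beyond the scatter), both exchange ((tert-butyl)sulfonyl)methyl for methanesulfonamido or 4-(methylsulfonyl)phenoxy; 3-fluorobutyl resembles none of these, so the evidence is thin. The step of a number 13 percentage points lower from compound 3 to compound 4 (beyond the scatter) in this assay is expected, a modest fall with wide uncertainty. Compound 4 is estimated at 15%, between 0% and 35%.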

Compound 4, a percentage reported as inhibition, in the whole organism at one dose (the size of the read-out at that dose, not a potency): 51%
Beside the measured number, compound 4's estimate is 36 percentage points below it, outside the stated range (above it).
By their numbers in this assay, from the lowest: compound 1; then compounds 2 and 3 (each within the scatter of the next); then compound 4.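

Compound 4 is the only one of the series with a chain substituent carrying no sulfonyl group, and the change to 3-fluorobutyl, with no ring, raises the inhibition in this assay: a number 23 percentage points higher from compound 3 to compound 4 (beyond the scatter), a number 24 percentage points higher from compound 2 to compound 4 (beyond the scatter) and a number 41 percentage points higher from compound 1 to compound 4 (beyond the scatter). The position therefore accepts a small fluorinated alkyl group, and the sulfonyl-bearing groups are not needed for the effect at this dose. Nothing on hand explains the gain.

The compounds shown leave open whether the fluorine or the loss of the sulfonyl group carries the rise. On these data alone, how a plain butyl chain, a longer chain or an amine would compare at this place also remains open.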